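Pyrazole for thiophene on the benzyl arm of compound 3

The compounds below may be only part of what the source reports. "The series", "measured", "known", "first", "only" and "open" are said of these compounds alone.

Measured so far:
compound 1, `O=C(Nc1c(F)cc(F)cc1F)N(Cc1ccc(-c2cccs2)cc1)C1CCCCCC1` — 18 nM
compound 2, `Cc1cc(C)c(NC(=O)N(Cc2ccc(-c3nnc(C)o3)cc2)C2CCCCCC2)c(C)c1` — 27 nM
compound 3, `Cc1cc(C)c(NC(=O)N(Cc2ccc(-c3cccs3)cc2)C2CCCCCC2)c(C)c1` — 22 nM

In an assay on microsomes from intestine for inhibition of acyl-CoA:cholesterol acyltransferase (Oryctolagus cuniculus) (a higher number here means a weaker inhibitor, a lower number a stronger inhibitor), compound 3 holds the second highest of the three numbers. Its nearest neighbour is compound 1, with a 1.2-fold higher number from compound 1 to compound 3 (0.09 log units; within the scatter); the furthest is compound 2, with a 1.2-fold lower number from compound 2 to compound 3 (0.09 log units; within the scatter). Both steps sit within the scatter, so the three measured compounds are not separated from each other.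

Compound 4, `Cc1cc(C)c(NC(=O)N(Cc2ccc(-c3cc[nH]n3)cc2)C2CCCCCC2)c(C)c1`, differs from compound 3 by 1H-pyrazol-3-yl in place of thiophen-2-yl on an aromatic carbon. The step that bears on it most directly is a 1.2-fold lower number from compound 2 to compound 3 (0.09 log units; within the scatter), which exchanged one five-membered aromatic ring for another at the same aromatic carbon and stayed within the scatter. The change at the other end of the molecule, a 1.2-fold higher number from compound 1 to compound 3 (0.09 log units; within the scatter), was likewise within the scatter. For the measured compounds named here, no measured step involves a hydrogen-bond donor on this ring, so that part of the change has no precedent here.

The expected step in this assay is a 1.4-fold higher number from compound 3 to compound 4 (0.13 log units; within the scatter), that is, none beyond the scatter. Compound 4 is therefore estimated at 30 nM, with a range from 12 nM to 80 nM.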

Compound 4, half-maximal inhibitory concentration: 52 nM
Beside the measured number, compound 4's estimate is 1.7-fold (0.24 log units) below it; the measured number falls inside the stated range.
By their numbers in this assay, from the lowest: compounds 1, 3, 2 and 4 (each within the scatter of the next, the first and the last beyond it).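

In this assay, the aromatic carbon para to a large group now shows a ring exchange that goes beyond the scatter: 1H-pyrazol-3-yl in place of thiophen-2-yl gives a 2.4-fold higher number from compound 3 to compound 4 (0.37 log units; beyond the scatter), a modest step. Measured against the other ring at this position, 1H-pyrazol-3-yl in place of 5-methyl-1,3,4-oxadiazol-2-yl gives a 1.9-fold higher number from compound 2 to compound 4 (0.28 log units; within the scatter), which stays within the scatter, so the pyrazole is separated from the thiophene only. The pyrazole is the one ring of the three with a hydrogen-bond donor, but nothing available bears on what lies behind the step.

Still open, from the compounds shown here alone, is whether that step follows the ring hydrogen, which a 1-methylpyrazol-3-yl ring at the same carbon would test. Also open, going by these compounds, is whether it carries over to the 2,4,6-trifluorophenyl side of the series.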